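A few compounds are considered here, and "the series" means these few. Any claim that something is new, unique, unknown or untested is made for them only; others in the source may bear on it.

Compound 1 `O=C1c2c[n+]([O-])c3ccccc3c2C(=O)c2c1c1ccccc1n2Cc1cn([C@H]2O[C@H](CO)[C@@H](O)[C@H]2O)nn1`: 1700 nM
Compound 2 `O=C1c2c[n+]([O-])c3ccccc3c2C(=O)c2c1c1ccccc1n2CCCCn1ccnc1`: 210 nM
Compound 3 `CCCCN1CCN(CCCCn2c3c(c4ccccc42)C(=O)c2c[n+]([O-])c4ccccc4c2C3=O)CC1`: 900 nM

In a functional assay on MDA-MB-231 cells (Homo sapiens) for cytotoxicity, read by MTT assay, with a stated time of 72 h (on this read-out higher numbers stand for weaker inhibition and lower numbers for stronger inhibition), compound 2 gives 210 nM, the lowest of the three numbers, and both compound 3 and compound 1 lie beyond the scatter from it. Compound 4 `O=C1c2c[n+]([O-])c3ccccc3c2C(=O)c2c1c1ccccc1n2CCCCN1CCCCC1` has not yet been measured. It differs from compound 2 at a single place, with piperidin-1-yl in place of 1H-imidazol-1-yl on a saturated chain carbon, four bonds along the chain from an aromatic nitrogen.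

For the measured compounds named here, one measured step bears directly on this change. In a 4.3-fold higher number from compound 2 to compound 3 (0.63 log units; beyond the scatter), 4-butylpiperazin-1-yl replaces 1H-imidazol-1-yl at the same place. That step is modest but beyond the scatter. Going by the values given here, no measured compound carries piperidin-1-yl, so this single step is the only guide, and the expectation is correspondingly loose. A step in the same direction in this assay, of similar or somewhat smaller size, is expected. The estimated step is a 2.9-fold higher number from compound 2 to compound 4 (0.46 log units; beyond the scatter). Compound 4 is expected to give 600 nM, with an estimated range of 250 nM to 1500 nM.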

Compound 4, half-maximal inhibitory concentration: 610 nM
The estimate for compound 4 lay 1.0-fold (0.01 log units) below the measured number; the measured number falls inside the stated range.
By their numbers in this assay, from the lowest: compound 2; then compounds 4, 3 and 1 (each within the scatter of the next, the first and the last beyond it).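

In this assay, the step of a 2.9-fold higher number from compound 2 to compound 4 (0.46 log units; beyond the scatter) gives a second case in which a six-membered non-aromatic ring in place of 1H-imidazol-1-yl, on a saturated chain carbon, four bonds along the chain from an aromatic nitrogen, goes with a higher number beyond the scatter, so the earlier step from compound 2 no longer stands alone. The step of a 1.5-fold lower number from compound 3 to compound 4 (0.17 log units; within the scatter) lies within the scatter, so at this place the assay does not separate piperidin-1-yl from 4-butylpiperazin-1-yl, and the butyl-bearing ring shows no measurable effect of its own in this comparison. No measured property is available to explain either step.

The compounds shown leave open whether the higher numbers follow the change from a five-membered aromatic ring to a non-aromatic ring or the change in ring size, a question that pyrrolidin-1-yl, a five-membered non-aromatic ring, at the same place could help to separate. Going by these compounds, it also remains open whether the same steps would hold for morpholin-4-yl or on a shorter or longer chain.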